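The source may report more compounds than this note shows. Statements on the series, on what has been measured and on what is new or still open speak of the compounds shown alone.

Measured compounds in an assay on HL-60 cells for agonist activity at vitamin D3 receptor (Homo sapiens), read by microscopy, with a stated time of 96 h; a lower number here means that less compound is needed, a higher number that more compound is needed for the effect: compound 1 `CCn1c(C(=O)NCCN(C)C)ccc1C(CC)(CC)c1ccc(OCC(=O)C(C)(C)C)c(C)c1` gives 77 nM; compound 2 `CCOC(=O)CN(C)C(=O)c1ccc(C(CC)(CC)c2ccc(OCC(O)C(C)(C)C)c(C)c2)n1CC` gives 210 nM; compound 3 `CCN(CC)CCNC(=O)c1ccc(C(CC)(CC)c2ccc(OCC(O)C(C)(C)C)c(C)c2)n1CC` gives 110 nM.

Compound 3 stands second highest of the three numbers, nearer to compound 1 than to compound 2 and within the scatter of both. Compound 4 `CCn1c(C(=O)NCCN(C)C)ccc1C(CC)(CC)c1ccc(OCC(O)C(C)(C)C)c(C)c1` differs from compound 3 by dimethylamino in place of diethylamino on a saturated chain carbon, two bonds along the chain from an amide-type nitrogen. Among the measured compounds shown here, the one measured step that alters the amide substituent, a 1.9-fold lower number from compound 2 to compound 3 (0.28 log units; within the scatter), exchanged the whole amine-bearing group and still stayed within the scatter, so the smaller exchange here is expected to give no step beyond the scatter in this assay in either direction. The estimate for compound 4 is 100 nM, with a range of 50 nM to 200 nM, meaning an expected step of a 1.1-fold lower number from compound 3 to compound 4 (0.04 log units; within the scatter).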

Compound 4, half-maximal effective concentration: 14 nM
The estimate for compound 4 lay 7.1-fold (0.85 log units) above the measured number, and the stated range ends above it.
By their numbers in this assay, from the lowest: compound 4; then compounds 1, 3 and 2 (each within the scatter of the next, the first and the last beyond it).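

In this assay, the terminal amine proves to matter: dimethylamino in place of diethylamino alone gives a 7.9-fold lower number from compound 3 to compound 4 (0.90 log units; beyond the scatter) and thus a step beyond the scatter, which the earlier amide change did not show. The wider amide exchange gives a 15-fold lower number from compound 2 to compound 4 (1.18 log units; beyond the scatter) in the same direction. A second place also counts, as 1-hydroxy-2,2-dimethylpropyl in place of (tert-butyl)carbonyl gives a 5.5-fold lower number from compound 1 to compound 4 (0.74 log units; beyond the scatter) with the same 2-(dimethylamino)ethyl amide retained. Going by these compounds, whether a primary amine or a longer chain between the amide nitrogen and the dimethylamino group would hold this number remains open. No measurement offered here accounts for these steps.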